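Moving the chlorine on the benzyl group of compound 3

The source may hold more compounds than are shown below. What is called first, only, known or untested is meant among the compounds shown, and "the series" means these compounds.

In an ADME assay on MT4 cells (Homo sapiens) for cytotoxicity, read by MTT assay, with a stated time of 5 days (a higher number here means that more compound is tolerated, a lower number that less compound is tolerated), compound 3 (`O=C1N(Cc2ccccc2Cl)c2cccn2S(=O)(=O)N1Cc1cccc(F)c1`) gives 231000 nM. That lies within the scatter of compound 2 (`O=C1N(Cc2cccc(Cl)c2)c2cccn2S(=O)(=O)N1Cc1ccccc1`), which gives 196000 nM. Compound 1 (`N#Cc1ccccc1CN1C(=O)N(Cc2cccc(F)c2)S(=O)(=O)n2cccc21`) reads > 305000 nM, which is a limit of the assay and not a number.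

Compound 4 (`O=C1N(Cc2cccc(Cl)c2)c2cccn2S(=O)(=O)N1Cc1cccc(F)c1`) has the same atoms as compound 3, joined differently: 3-chlorophenyl in place of 2-chlorophenyl on a saturated chain carbon bound to an amide-type nitrogen in a ring. Put simply, 3-chlorobenzyl replaces 2-chlorobenzyl.

Within the data shown here, only one measured step bears on this place, and it swaps a group on the same benzyl rather than moving one: an at least 1.3-fold lower number from compound 1 to compound 3 (0.12 log units; that floor lies within the scatter). It gives no sign of a large effect here. The entering 3-chlorobenzyl also appears in compound 2, at 196000 nM in this assay, so that value offers a second guide.

The expected change is therefore a 1.1-fold lower number from compound 3 to compound 4 (0.03 log units; within the scatter), with no step beyond the scatter anticipated. Compound 4 is estimated at 215000 nM, with an expected range from 125000 nM to 320000 nM.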

Compound 4, half-maximal cytotoxic concentration: 208000 nM
For compound 4 the middle estimate is 1.0-fold (0.01 log units) above the measured one; measured number inside the range.
By their numbers in this assay, from the lowest: compounds 2, 4 and 3 (each within the scatter of the next). At a limit, above all of these: compound 1.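

In this assay, 3-chlorobenzyl in place of 2-chlorobenzyl gives a 1.1-fold lower number from compound 3 to compound 4 (0.05 log units; within the scatter), so where the chlorine sits on this benzyl group makes no difference beyond the scatter among these compounds. Fluoro in place of hydrogen on an aromatic carbon, a change not seen in a single step until now, gives a 1.1-fold higher number from compound 2 to compound 4 (0.03 log units; within the scatter), which also stays within the scatter. The change from 2-cyanophenyl to 3-chlorophenyl gives an at least 1.4-fold lower number from compound 1 to compound 4 (0.16 log units; that floor lies within the scatter), but only a floor can be read, because compound 1 stands at a limit of the assay: the limit of > 305000 nM in this assay, at which 1 of the 4 values shown sits.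

As far as these compounds go, how far compound 1 truly lies from the other compounds remains open. So does whether an amine, a carboxylic acid or a longer chain at this place would shift the tolerated concentration beyond the scatter.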